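Swapping tert-Butyl for Chloro: Expecting Little Change

The source may hold more compounds than are shown below. What is called first, only, known or untested is meant among the compounds shown, and "the series" means these compounds.

Compound 1 `C=C(c1ccc(OC)cc1)c1cc(OC)c(OC)c(OC)c1-c1ccc(OC)cc1` in a functional assay on DU-145 cells (Homo sapiens) for cytotoxicity, read by MTT assay, with a stated time of 48 h (on this read-out higher numbers stand for weaker inhibition and lower numbers for stronger inhibition), gives 37000 nM.
Compound 2 `C=C(c1ccc(OC)cc1)c1cc(OC)c(OC)c(OC)c1-c1ccc(C(C)(C)C)cc1` in this assay gives 39000 nM.

Compound 2 sits within the scatter of compound 1, so on these two numbers it does not stand apart. Compound 3 `C=C(c1ccc(OC)cc1)c1cc(OC)c(OC)c(OC)c1-c1ccc(Cl)cc1` differs from compound 2 by chloro in place of tert-butyl on an aromatic carbon. For the measured compounds named here, the only measured step at this same spot, a 1.1-fold higher number from compound 1 to compound 2 (0.02 log units; within the scatter), moved nothing beyond the scatter, and no measured compound carries a chloro there. Compound 3 is therefore expected to show a 1.0-fold lower number from compound 2 to compound 3 (0.01 log units; within the scatter), no step beyond the scatter. Compound 3 is estimated at 38000 nM, within 14000 nM to 100000 nM.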

Compound 3, half-maximal inhibitory concentration: 33000 nM
Estimate against measurement, compound 3: 1.2-fold (0.06 log units) above; the range from low to high includes it.
By their numbers in this assay, from the lowest: compounds 3, 1 and 2 (each within the scatter of the next).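

With a 1.2-fold lower number from compound 2 to compound 3 (0.07 log units; within the scatter) and a 1.1-fold lower number from compound 1 to compound 3 (0.05 log units; within the scatter) on moving to chloro, three different groups have now sat at this spot on the aromatic ring without the number leaving the scatter. Even going from four heavy atoms in tert-butyl to the single one in chloro leaves this assay unable to tell the compounds apart. As far as these compounds go, whether an amine, a carboxylic acid or a longer chain here would shift the number stays open, as does what other parts of the shared core contribute. No measured evidence is available to explain this flat result.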